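A Carbamate Replaces the Methoxyphenoxypropyl Chain

This account rests on a few compounds, and the source may have more. Where it says the series, first, only, none or still open, it means among the compounds named here.

In a functional assay on PANC-1 cells (Homo sapiens) for inhibition, read by MTT assay, with a stated time of 24 h, tested at 10 uM (on this read-out lower numbers stand for less inhibition and higher numbers for more inhibition at the one concentration tested (going by the name of the read-out)), compound 3 `COc1ccc(OCCCOc2cc(=O)n(CCCO)c3c2CC(C/C=C(\C)CCC=C(C)C)C(C)(C)C3)cc1` gives 20%, the lowest of the three measured numbers. In this assay compound 1 `CC(C)=CCC/C(C)=C/CC1Cc2c(OCCCNC(=O)c3ccco3)cc(=O)n(CCCO)c2CC1(C)C` gives 69.5% and compound 2 `CC(C)=CCC/C(C)=C/CC1Cc2c(OCCCNC(=O)c3cccs3)cc(=O)n(CCCO)c2CC1(C)C` gives 72.8%; between them lies a number 3.3 percentage points higher from compound 1 to compound 2 (within the scatter). The two large steps are a number 49.5 percentage points lower from compound 1 to compound 3 (beyond the scatter) and a number 52.8 percentage points lower from compound 2 to compound 3 (beyond the scatter). Compound 4 `CC(C)=CCC/C(C)=C/CC1Cc2c(OC(=O)Nc3ccc(Cl)cc3)cc(=O)n(CCCO)c2CC1(C)C` differs from compound 3 in this way: (4-chlorophenyl)carbamoyl in place of 3-(4-methoxyphenoxy)propyl on an oxygen on an aromatic ring. Within the data shown here, no measured step matches this change directly; the measured steps show only that the 3-(4-methoxyphenoxy)propyl group stands with the lowest number and that compound 1 with an amide-bearing side chain gives 69.5%. A return upward in this assay is therefore expected for compound 4, by about a number 30 percentage points higher from compound 3 to compound 4 (beyond the scatter), with wide uncertainty. The estimate for compound 4 is 50%, ranging from 20% to 80%.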

Compound 4, a percentage reported as inhibition, at one concentration (the size of the read-out at that concentration, not a potency): 47.2%
The estimate for compound 4 lay 2.8 percentage points above the measured number, within the range that was stated.
By their numbers in this assay, from the lowest: compound 3; then compound 4; then compounds 1 and 2 (each within the scatter of the next).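

In this assay there is a number 27.2 percentage points higher from compound 3 to compound 4 (beyond the scatter) for this change, so this oxygen on an aromatic ring can carry a group without a propyl chain and still stand clear of compound 3. The 3-acylaminopropyl groups nevertheless stay ahead, with a number 22.3 percentage points lower from compound 1 to compound 4 (beyond the scatter) and a number 25.6 percentage points lower from compound 2 to compound 4 (beyond the scatter) on replacing them with (4-chlorophenyl)carbamoyl. No evidence is available to explain this order. The compounds shown leave open whether the carbamoyl link or the chlorine carries the step, and how a plain phenylcarbamoyl group or a longer chain bearing the furan-2-yl amide would stand.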